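The source may hold more compounds than are shown below. What is called first, only, known or untested is meant among the compounds shown, and "the series" means these compounds.

Three compounds have been measured in a functional assay on OVCAR-3 cells (Homo sapiens) for inhibition, read by sulforhodamine B assay, with a stated time of 48 h; on this read-out lower numbers stand for stronger inhibition of growth and higher numbers for weaker inhibition of growth:

- compound 1, `COc1cc(-c2nn(-c3cccc(NC(=O)Nc4cc(C(F)(F)F)cc(C(F)(F)F)c4)c3)cc2-c2ccncc2)ccc1Cl`, which gives 411 nM
- compound 2, `O=C(Nc1cccc(-n2cc(-c3ccncc3)c(-c3ccc(Cl)c(O)c3)n2)c1)Nc1cc(C(F)(F)F)cc(C(F)(F)F)c1`, which gives 395 nM
- compound 3, `COc1cc(-c2nn(-c3cccc(NC(=O)Nc4ccc(Cl)c(C(F)(F)F)c4)c3)cc2-c2ccncc2)ccc1Cl`, which gives 889 nM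

Compound 1 and compound 2 share a core and differ in one place: hydrogen in place of methyl on an oxygen on an aromatic ring. This change made a 1.0-fold lower number from compound 1 to compound 2 (0.02 log units; within the scatter), so the two compounds cannot be told apart on this read-out. Compound 3 carries a different group on the urea; the difference between its core and the core of compound 1 is not broken down here. Its number is the highest of the three, and its gap to compound 1 and to compound 2 lies beyond the usual scatter.

Compound 4, `O=C(Nc1cccc(-n2cc(-c3ccncc3)c(-c3ccc(Cl)c(O)c3)n2)c1)Nc1ccc(Cl)c(C(F)(F)F)c1`, is not yet measured. It differs from compound 3 in one place: hydrogen in place of methyl on an oxygen on an aromatic ring. The place is described in the same words as for the change from compound 1 to compound 2, so this is the same change, now made on the core of compound 3. Because that change made a 1.0-fold lower number from compound 1 to compound 2 (0.02 log units; within the scatter), the step from compound 3 to compound 4 is expected to be a 1.0-fold lower number from compound 3 to compound 4 (0.01 log units; within the scatter), a step that stays within the scatter. The estimate for compound 4 is therefore 870 nM, expected to fall between 400 nM and 1900 nM.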

Compound 4, concentration for 50% growth inhibition: 830 nM
Beside the measured number, compound 4's estimate is 1.0-fold (0.02 log units) above it; low and high end bracket the measured number.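

On the core of compound 3, going from methoxy to hydroxy gives a 1.1-fold lower number from compound 3 to compound 4 (0.03 log units; within the scatter) in this assay, so this pair cannot be told apart on this read-out, just like the earlier pair. Set side by side, the two steps agree: the same change on two cores in this assay, a 1.0-fold lower number (0.02 log units; within the scatter) from compound 1 to compound 2 and a 1.1-fold lower number (0.03 log units; within the scatter) from compound 3 to compound 4, 1.0-fold (0.01 log units) apart, within the scatter of two such steps This shows that, on these two cores, the change from 4-chloro-3-methoxyphenyl to 4-chloro-3-hydroxyphenyl makes no step that this read-out can detect, but two cores are a small sample and do not show that the same would hold on every core in the series.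

The compounds shown leave open whether other groups on that oxygen, such as an ethyl group or a longer chain, or an amine in place of the hydroxy, would also stay within the scatter. They also leave open whether the step stays this small on a core that carries a different group on the urea, such as a carboxylic acid.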